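This account rests on a few compounds, and the source may have more. Where it says the series, first, only, none or still open, it means among the compounds named here.

Compound 3 `CN1CCN(c2ccc(Nc3nc(-c4cccc(NC(=O)c5ccc(C(C)(C)C)cc5)c4)sc3C(N)=O)cc2)CC1` stands lowest among the three measured compounds: in a functional assay on Raji cells (Homo sapiens) for antiproliferative activity, read by CCK-8 assay, with a stated time of 72 h, tested at 40 uM (a higher number here means more inhibition at the concentration tested (going by the name of the read-out), a lower number less inhibition), compound 3 gives 12.1%. Its nearest neighbour on the numbers is compound 1 `CN1CCN(c2ccc(Nc3nc(-c4cccc(NC(=O)c5ccccc5F)c4)sc3C(=O)O)cc2)CC1`, which in this assay gives 86.9%, and the furthest is compound 2 `CN1CCN(c2ccc(Nc3nc(-c4cccc(NC(=O)c5ccc(F)cc5)c4)sc3C(N)=O)cc2)CC1`, which gives 95.3%. The step from compound 4 `CN1CCN(c2ccc(Nc3nc(-c4cccc(NC(=O)c5ccccc5F)c4)sc3C(N)=O)cc2)CC1` back to compound 3 is a single change at one place: 2-fluorophenyl in place of 4-(tert-butyl)phenyl on a carbonyl carbon. Among the compounds with values here, one measured step bears on it directly, the change of fluoro to tert-butyl on an aromatic carbon, which gave a number 83.2 percentage points lower from compound 2 to compound 3 (beyond the scatter); compound 4 reverses that kind of change, returning to a fluoro-bearing ring. Compound 1 carries the same 2-fluorophenyl group on the carbonyl carbon as compound 4 and differs from it only elsewhere, and its value sits close to that of compound 2. The expected step from compound 3 to compound 4 is therefore a large rise, a number 76.9 percentage points higher from compound 3 to compound 4 (beyond the scatter). Compound 4 is estimated to give 89% in this assay, with a range from 72% to 98%.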

Compound 4, a percentage reported as inhibition, at one concentration (the size of the read-out at that concentration, not a potency): 97.3%
Estimate against measurement, compound 4: 8.3 percentage points below, within the range that was stated.
By their numbers in this assay, from the lowest: compound 3; then compounds 1, 2 and 4 (each within the scatter of the next, the first and the last beyond it).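

In this assay, 2-fluorophenyl in place of 4-(tert-butyl)phenyl on the carbonyl carbon gives a number 85.2 percentage points higher from compound 3 to compound 4 (beyond the scatter), and 2-fluorophenyl in place of 4-fluorophenyl gives a number 2 percentage points higher from compound 2 to compound 4 (within the scatter), so the high values are not confined to the 4-fluorophenyl group of compound 2 and the two fluorophenyl groups cannot be told apart here. With the 2-fluorophenyl group held fixed, the other site also registers: amino in place of hydroxy on the carbonyl carbon gives a number 10.4 percentage points higher from compound 1 to compound 4 (beyond the scatter). No measurement at hand explains any of these steps. As far as these compounds go, it remains open whether a plain phenyl, a 4-methylphenyl or a cyclohexyl group on the carbonyl carbon would side with compound 3 or compound 4. From the compounds shown here alone, it is also open whether a carboxylic acid would change the value of the 4-(tert-butyl)phenyl compound.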